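Amide aryl variation in a flavonol series: compound 4

The compounds below may be only part of what the source reports. "The series", "measured", "known", "first", "only" and "open" are said of these compounds alone.

Measured compounds:
compound 1, `O=C(Nc1cccc(-c2oc3cc(-c4ccc(F)cc4)ccc3c(=O)c2O)c1)c1ccc(F)cc1`, 14600 nM
compound 2, `COc1ccc(C(=O)Nc2cccc(-c3oc4cc(-c5ccc(F)cc5)ccc4c(=O)c3O)c2)cc1`, 21100 nM
compound 3, `CCc1ccc(C(=O)Nc2cccc(-c3oc4cc(-c5ccc(F)cc5)ccc4c(=O)c3O)c2)cc1`, 24600 nM

All three values come from a functional assay on GTL 16 cells for antiproliferative activity against GTL 16 cell line (Homo sapiens), read by CCK-8 assay, with a stated time of 72 h; a higher number here means a weaker inhibitor, a lower number a stronger inhibitor. Compound 2 stands second highest of the three numbers; its nearest neighbour is compound 3, with a 1.2-fold higher number from compound 2 to compound 3 (0.07 log units; within the scatter), and its furthest is compound 1, with a 1.4-fold higher number from compound 1 to compound 2 (0.16 log units; within the scatter). The third pairing, a 1.7-fold higher number from compound 1 to compound 3 (0.23 log units; within the scatter), is likewise within the scatter, so the three measured compounds show no separation that can be read as a difference in potency.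

Compound 4, `COc1cc(OC)cc(C(=O)Nc2cccc(-c3oc4cc(-c5ccc(F)cc5)ccc4c(=O)c3O)c2)c1`, has not yet been measured. The change from compound 2 is 3,5-dimethoxyphenyl in place of 4-methoxyphenyl on a carbonyl carbon. Going by the values given here, the steps that bear on it are those in which the group on the amide carbonyl was varied: a 1.4-fold higher number from compound 1 to compound 2 (0.16 log units; within the scatter), a 1.7-fold higher number from compound 1 to compound 3 (0.23 log units; within the scatter) and a 1.2-fold higher number from compound 2 to compound 3 (0.07 log units; within the scatter), none of them beyond the scatter. Nothing in the measured set isolates the effect of a second methoxy, as in the entering 3,5-dimethoxyphenyl, so the expectation rests on the flatness of the series as a whole.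

In this assay compound 4 is therefore expected to give 22000 nM, with a range from 11000 nM to 45000 nM, meaning an expected step of a 1.0-fold higher number from compound 2 to compound 4 (0.02 log units; within the scatter).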

Compound 4, half-maximal inhibitory concentration: 19600 nM
Compound 4: the middle estimate sits 1.1-fold (0.05 log units) above what was measured; the range from low to high includes it.
By their numbers in this assay, from the lowest: compounds 1, 4, 2 and 3 (each within the scatter of the next).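

In this assay, going by these compounds alone, the change to 3,5-dimethoxyphenyl in place of 4-methoxyphenyl on a carbonyl carbon gives a 1.1-fold lower number from compound 2 to compound 4 (0.03 log units; within the scatter), the first reading on a second methoxy, and it stays within the scatter. Within the data shown here, the comparisons with the other two amide groups give a 1.3-fold lower number from compound 3 to compound 4 (0.10 log units; within the scatter) and a 1.3-fold higher number from compound 1 to compound 4 (0.13 log units; within the scatter), so the disubstituted ring also stays within the scatter of the 4-ethylphenyl and 4-fluorophenyl groups, and the four aryl groups on this carbonyl carbon show no separation in potency, with no compound going against that reading. No measurement available here offers an explanation for this flat result.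

Still open, on these data alone, is whether a non-aromatic group such as cyclohexyl, a carboxylic acid, or an amine such as morpholine on this carbonyl carbon would move the number beyond the scatter. The shared core is the same in all four compounds, so what a change to it, or to the amide linkage itself, would do in this assay also remains to be seen.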